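The source may hold more compounds than are shown below. What is called first, only, known or untested is meant among the compounds shown, and "the series" means these compounds.

Going by the values given here, compound 2 `Cc1cc(C)c(-c2ccc(N)cn2)cc1NC(=O)c1ccc(OCc2ccccn2)cc1` is one of two compounds measured in a physicochemical assay for solubility, at pH 7.4; on this read-out higher numbers stand for higher solubility and lower numbers for lower solubility. In this assay compound 2 gives < 1000 nM, which is a limit of the assay rather than a number. The related compound 1 `Cc1cc(C)c(-c2nc3ccccc3[nH]2)cc1NC(=O)c1ccc(OCc2ccccn2)cc1` carries a 1H-benzimidazol-2-yl group where compound 2 carries a 5-aminopyridin-2-yl group. In this assay compound 1 also gives < 1000 nM, again a limit. The step between them, a step that the two limits leave unreadable from compound 1 to compound 2, cannot be read, because both values sit at the limit (the limit of < 1000 nM in this assay, at which 2 of the 2 values shown sit). Compound 3 `Cc1cc(C)c(-c2cccc(N)n2)cc1NC(=O)c1ccc(OCc2ccccn2)cc1` has not yet been measured. It differs from compound 2 in one place: 6-aminopyridin-2-yl in place of 5-aminopyridin-2-yl on an aromatic carbon. The two have the same atoms, joined differently. Among the compounds with values here, no measured step speaks directly to this change, and the only step available is unreadable. The step expected in this assay is a step that the limit leaves unreadable from compound 2 to compound 3, nothing beyond the scatter, so compound 3 is expected to sit at the limit as well. For compound 3 the estimate in this assay is 500 nM, with a range from 100 nM to 2500 nM.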

Compound 3, solubility: 2000 nM
For compound 3 the middle estimate is 4.0-fold (0.60 log units) below the measured one; the measured number falls inside the stated range.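

Until this result nothing could be read at this place, on an aromatic carbon ortho to a methyl group, because compound 1 and compound 2 stopped at the same limit: the limit of < 1000 nM in this assay, at which 2 of the 3 values shown sit.

Compound 3 gives a number rather than a limit, and in this assay putting 6-aminopyridin-2-yl in place of 5-aminopyridin-2-yl, the same atoms joined differently, comes with an at least 2.0-fold higher number from compound 2 to compound 3 (0.30 log units; that floor lies within the scatter). Putting 6-aminopyridin-2-yl in place of 1H-benzimidazol-2-yl at the same place comes with an at least 2.0-fold higher number from compound 1 to compound 3 (0.30 log units; that floor lies within the scatter), so both steps are now readable as floors, though neither floor clears the usual scatter on its own.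

As far as these compounds go, the full size of both steps stays open, since only their floors can be read. Also open, from the compounds shown here alone, is whether the amine itself matters at the position it holds in compound 3, which a plain pyridin-2-yl ring, or a methylamino group or a carboxylic acid in place of the amine on that ring, could begin to show.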